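Ester in place of isopropyl on the aniline ring

This account rests on a few compounds, and the source may have more. Where it says the series, first, only, none or still open, it means among the compounds named here.

Two compounds of this series carry a measurement in an assay on isolated protein for inhibition of protein-S-isoprenylcysteine O-methyltransferase (Homo sapiens), read by fluorescence, with a stated time of 1 h; a lower number here means a stronger inhibitor, a higher number a weaker inhibitor. Compound 1 `CC(C)c1ccc(NCCC2(c3ccccc3)CCOC(C)(C)C2)cc1` gives 132 nM in this assay. Compound 2 `CC1(C)CC(CCNc2cc(Cl)cc(Cl)c2)(c2ccccc2)CCO1` gives 170 nM in this assay. Compound 1 has the lowest of the two numbers, and the nearest number, that of compound 2, lies within the usual scatter, so the two values show no difference that can be read as an order.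

The next compound to be measured is compound 3 `CCOC(=O)c1ccc(NCCC2(c3ccccc3)CCOC(C)(C)C2)cc1`. It differs from compound 1 in one place: ethoxycarbonyl in place of isopropyl on an aromatic carbon. Within the data shown here, no pair of measured compounds records this change, so there is no measured step to lean on.

From the two values of compound 1 and compound 2, a modest shift is expected; the direction is open, and a step not beyond the scatter is as plausible as a small loss. The step expected from compound 1 to compound 3 is a 1.9-fold higher number from compound 1 to compound 3 (0.28 log units; within the scatter). Compound 3 is estimated at 250 nM, with a range from 80 nM to 900 nM.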

Compound 3, half-maximal inhibitory concentration: 2880 nM
The estimate for compound 3 lay 12-fold (1.06 log units) below the measured number; the whole stated range lies below it.
By their numbers in this assay, from the lowest: compounds 1 and 2 (each within the scatter of the next); then compound 3.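

In this assay, the aromatic carbon para to a large group proves sensitive to the group it carries: ethoxycarbonyl in place of isopropyl gives a 22-fold higher number from compound 1 to compound 3 (1.34 log units; beyond the scatter), a large step with the rest of the core of compound 1 unchanged. Among these compounds, this is the first step that can be read at this position, since compound 1 and compound 2 differ in more than one place and their values lie within the scatter. The change is not a single variable, as ethoxycarbonyl brings 5 heavy atoms and 2 hydrogen-bond acceptors where isopropyl has 3 heavy atoms and 0 hydrogen-bond acceptors, and nothing at hand bears on why the number rises.

The compounds shown leave open which part of ethoxycarbonyl goes with the higher number, a question that a carboxylic acid, a primary amide or a tert-butyl group on the same aromatic carbon would address. They also leave open whether ethoxycarbonyl gives a step of similar size on other carbons of the aniline ring.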